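The compounds below may be only part of what the source reports. "The series", "measured", "known", "first", "only" and "open" are said of these compounds alone.

Measured in a functional assay on MCF-10A cells (Homo sapiens) for antiproliferative activity, with a stated time of 48 h; on this read-out higher numbers stand for an effect only at larger amounts of compound and lower numbers for an effect already at smaller amounts:
- Compound 1 `COc1cccc(CNc2cc(C)nc3ccc(OC)cc23)c1`: 12500 nM
- Compound 2 `COc1ccc2nc(C)cc(NCc3cccc(C#N)c3)c2c1`: 17400 nM

With only these two values, compound 2, at 17400 nM, stands within the scatter of compound 1. Compound 3 `Cc1cc(NCc2cccc(C#N)c2)c2cc(OCCCN3CCCC3)ccc2n1` differs from compound 2 by 2-(pyrrolidin-1-yl)ethyl in place of hydrogen on a saturated chain carbon bound to an oxygen on an aromatic ring, which turns methoxy into 3-(pyrrolidin-1-yl)propoxy.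

Within the data shown here, the only measured step, a 1.4-fold higher number from compound 1 to compound 2 (0.14 log units; within the scatter), is a different change, cyano in place of methoxy, and stayed within the scatter. It therefore offers no direct guide to the new group, and a lower number in this assay is a judgement resting on the size of the added group. The expected change is a 5.8-fold lower number from compound 2 to compound 3 (0.76 log units; beyond the scatter). For compound 3 the estimated value is 3000 nM, with an expected range of 500 nM to 15000 nM.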

Compound 3, half-maximal effective concentration: 10300 nM
For compound 3 the middle estimate is 3.4-fold (0.54 log units) below the measured one, and the stated range covers the measured number.
By their numbers in this assay, from the lowest: compounds 3, 1 and 2 (each within the scatter of the next).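

In this assay, turning methoxy into 3-(pyrrolidin-1-yl)propoxy gives a 1.7-fold lower number from compound 2 to compound 3 (0.23 log units; within the scatter), so this large addition, which brings in a five-membered non-aromatic ring, leaves the number inside the usual spread of repeats. Among these compounds, the earlier step changed a different place, cyano in place of methoxy, so this is the first reading at the saturated chain carbon bound to an oxygen on an aromatic ring, and it shows that this position tolerates a bulky extension without a clear loss or gain in antiproliferative effect. Nothing measured here bears on why the number stays within that spread.

On these data alone, whether a morpholine ring or a carboxylic acid at the end of the same chain would move the number beyond the scatter remains open. So does whether a shorter ethoxy linker to the pyrrolidine ring would behave like the propoxy one.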